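Hydrazone aryl swap: difluorophenyl to chlorophenyl

The source may report more compounds than this note shows. Statements on the series, on what has been measured and on what is new or still open speak of the compounds shown alone.

Compound 1 `CN(C)CCn1cnnc1-c1cc(Oc2ccc(NC(=O)N/N=C/c3ccccc3)cc2F)ccn1` gives "not determined" (no result reported) in an ADME assay on WI-38 cells (Homo sapiens) for cytotoxicity, read by MTT assay, with a stated time of 72 h (on this read-out higher numbers stand for weaker inhibition and lower numbers for stronger inhibition), that is, no result is reported for it. Compound 2 `CN(C)CCn1cnnc1-c1cc(Oc2ccc(NC(=O)N/N=C/c3ccc(F)cc3)cc2F)ccn1` gives 3980 nM in this assay. Compound 3 `CN(C)CCn1cnnc1-c1cc(Oc2ccc(NC(=O)N/N=C/c3ccc(F)cc3F)cc2F)ccn1` gives 5030 nM in this assay, the higher of the two numbers, with compound 2 nearest; the step of a 1.3-fold higher number from compound 2 to compound 3 (0.10 log units; within the scatter) stays within the scatter. Compound 4 `CN(C)CCn1cnnc1-c1cc(Oc2ccc(NC(=O)N/N=C/c3ccc(Cl)cc3)cc2F)ccn1` differs from compound 3 by 4-chlorophenyl in place of 2,4-difluorophenyl on a carbon with a double bond to nitrogen. Going by the values given here, the only measured step touching this aryl group is the one already named, and it produced no movement beyond the scatter; no step in the whole series moves beyond the scatter. The estimated step of a 1.1-fold lower number from compound 3 to compound 4 (0.05 log units; within the scatter) is therefore expected to be no change beyond the scatter. For compound 4 the expected value in this assay is 4500 nM, with a range from 2000 nM to 10000 nM.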

Compound 4, half-maximal inhibitory concentration: 1870 nM
Compound 4: middle estimate off by 2.4-fold (0.38 log units), on the high side; the measured number lies below the stated range.
By their numbers in this assay, from the lowest: compound 4; then compounds 2 and 3 (each within the scatter of the next).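

On this carbon with a double bond to nitrogen, the aryl group can shift the number in this assay beyond the scatter: a 2.7-fold lower number from compound 3 to compound 4 (0.43 log units; beyond the scatter) and a 2.1-fold lower number from compound 2 to compound 4 (0.33 log units; beyond the scatter). Adding a second fluoro did not do this, since a 1.3-fold higher number from compound 2 to compound 3 (0.10 log units; within the scatter) stays within the scatter, whereas the single exchange of chloro for fluoro on an aromatic carbon is enough. Nothing available here accounts for the shift.

Still open, going by these compounds, is whether 2,4-dichlorophenyl at this place goes further than 4-chlorophenyl. A bromo or methoxy group on the ring also remains to be placed relative to chloro.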